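Compound 2 to compound 3: one group exchanged

The source may report more compounds than this note shows. Statements on the series, on what has been measured and on what is new or still open speak of the compounds shown alone.

Compound 1 `CN(C)C(=O)c1cc(-c2cnc(NCc3c(F)ccc4c3CCO4)c3cn[nH]c(=O)c23)n(C)n1`: 2.1
Compound 2 `Cc1cc(-c2cnc(NCc3c(F)ccc4c3CCO4)c3cn[nH]c(=O)c23)n(C)n1`: 3

In a physicochemical assay for lipophilicity, using the shake flask method, in phosphate buffer, measured as octanol-water partition, with a stated time of 30 min, at pH 7.4 (on this read-out lower numbers stand for lower lipophilicity and higher numbers for higher lipophilicity), compound 2 stands highest of the two measured compounds. Compound 3 `CN(c1ccn(C)n1)c1cnc(NCc2c(F)ccc3c2CCO3)c2cn[nH]c(=O)c12` carries methyl(1-methyl-1H-pyrazol-3-yl)amino in place of 1,3-dimethyl-1H-pyrazol-5-yl on an aromatic carbon. For the measured compounds named here, the only measured step is a number 0.90 log units higher from compound 1 to compound 2 (beyond the scatter), with methyl in place of dimethylcarbamoyl. It concerns a different exchange and bears on this one only loosely, as a gauge of size. Both groups here hold one five-membered aromatic ring with 2 hetero atoms, and the estimated step of a number 0.20 log units lower from compound 2 to compound 3 (within the scatter) is expected to stay within the scatter. The estimate for compound 3 is 2.8, ranging from 2.3 to 3.3.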

Compound 3, distribution coefficient: 2.4
For compound 3 the middle estimate is 0.40 log units above the measured one; low and high end bracket the measured number.
By their numbers in this assay, from the lowest: compounds 1 and 3 (each within the scatter of the next); then compound 2.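

In this assay, the exchange of 1,3-dimethyl-1H-pyrazol-5-yl for methyl(1-methyl-1H-pyrazol-3-yl)amino gives a number 0.60 log units lower from compound 2 to compound 3 (beyond the scatter), so this position responds even when one five-membered aromatic ring with 2 hetero atoms stays in place. The same entering group, set against the 3-(dimethylcarbamoyl)-1-methyl-1H-pyrazol-5-yl of compound 1, gives a number 0.30 log units higher from compound 1 to compound 3 (within the scatter), so two quite different groups read alike here. No evidence at hand accounts for these steps. Going by these compounds, what a plain dimethylamino group or a morpholine on this aromatic carbon would give remains open.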